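Ester in place of hydroxyl on the lactone series

This account rests on a few compounds, and the source may have more. Where it says the series, first, only, none or still open, it means among the compounds named here.

compound 1 `C=C1C(=O)O[C@@H]2CC(C)=C([C@@H](C)CCCO)[C@H](O)[C@H]12`: 12.8%
compound 2 `CC(=O)OCCC[C@H](C)C1=C[C@@H]2[C@H](C)C(=O)O[C@@H]2C[C@@]1(C)O`: 4.28%

Both measured compounds were run in a functional assay on COLO 205 cells (Homo sapiens) for activation, read by flow cytometry, with a stated time of 24 h, tested at 25 uM; a lower number here means a weaker effect, a higher number a stronger effect of the compound at the concentration tested. In this assay compound 1 gives 12.8%, and compound 2 gives 4.28%. The gap between these two numbers lies within the usual scatter of the measurement, so neither compound is separated from the other on the evidence so far. For the measured compounds named here, no pair of measured compounds differs in a single place, so no measured step is available to guide the next change.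

Compound 3 `C=C1C(=O)O[C@@H]2CC(C)=C([C@@H](C)CCCO)[C@H](OC(=O)C(C)CC)[C@H]12` is the compound not yet measured. It differs from compound 1 by (sec-butyl)carbonyl in place of hydrogen on an oxygen on a saturated carbon. With no measured step of this kind in the series, the expected step of a number 7.2 percentage points higher from compound 1 to compound 3 (within the scatter) is taken to be of modest size and more likely upward than downward, though a change within the scatter is entirely possible. Compound 3 is estimated at 20%, within a range from 5% to 45%.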

Compound 3, a percentage reported as activity, at one concentration (the size of the read-out at that concentration, not a potency): 15.2%
Compound 3: middle estimate off by 4.8 percentage points, on the high side; low and high end bracket the measured number.
By their numbers in this assay, from the lowest: compounds 2, 1 and 3 (each within the scatter of the next, the first and the last beyond it).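

The hydroxy on the saturated carbon of compound 1 tolerates (sec-butyl)carbonyl in place of its hydrogen without a separable change in this assay: the step is a number 2.4 percentage points higher from compound 1 to compound 3 (within the scatter). For the compounds shown here, this is the first comparison between compounds that differ in one place, and on this evidence the ester at this oxygen neither gains nor loses a measurable effect at the concentration tested. Nothing available bears on the reason for this outcome.

Going by these compounds, whether a group of another kind on this oxygen, such as a carboxylic acid or a longer chain ending in an amine, would move the read-out beyond the scatter remains open. Also open, on these data alone, is whether (sec-butyl)carbonyl would give a similar result on another oxygen of the shared core.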